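This account rests on a few compounds, and the source may have more. Where it says the series, first, only, none or still open, it means among the compounds named here.

Measured compounds:
compound 1, `O=C(CC[C@H](NC(=O)c1cc2ccccc2cn1)C(=O)OCc1ccccc1)OCc1ccccc1`, 214 nM
compound 2, `CSCC[C@H](NC(=O)c1cc2ccccc2cn1)C(=O)OCc1ccccc1`, 309 nM

Both were read in a functional assay on HeLa cells (Homo sapiens) for antiproliferative activity, read by MTT assay, with a stated time of 48 h; on this read-out lower numbers stand for stronger inhibition and higher numbers for weaker inhibition. Compound 2 stands with the highest of the two numbers; its nearest neighbour is compound 1, and the step of a 1.4-fold higher number from compound 1 to compound 2 (0.16 log units; within the scatter) keeps the two within the scatter. That step exchanged benzyloxycarbonyl for methylsulfanyl on a saturated chain carbon, three bonds along the chain from an amide-type nitrogen and a carbonyl carbon, so the shared core tolerates a large change at the end of that chain without a shift beyond the scatter.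

Compound 3, `C[C@H](NC(=O)c1cc2ccccc2cn1)C(=O)OCc1ccccc1`, carries the same core and the same benzyl ester but differs from compound 2 by hydrogen in place of (methylsulfanyl)methyl on a saturated chain carbon, two bonds along the chain from an amide-type nitrogen and a carbonyl carbon. Among the measured compounds shown here, this removes the whole chain rather than trimming its end, and no measured step in this assay covers such a cut. For the measured compounds named here, only the step from compound 1 to compound 2 bears on it, and it was within the scatter. The expectation for compound 3 is therefore a step of a 1.9-fold higher number from compound 2 to compound 3 (0.29 log units; within the scatter) in this assay, towards a higher number but with wide uncertainty. Compound 3 is estimated at 600 nM, within 200 nM to 2500 nM.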

Compound 3, half-maximal inhibitory concentration: 154 nM
The estimate for compound 3 lay 3.9-fold (0.59 log units) above the measured number; measured number outside the range, below it.
By their numbers in this assay, from the lowest: compounds 3, 1 and 2 (each within the scatter of the next).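

In this assay, hydrogen in place of (methylsulfanyl)methyl on a saturated chain carbon, two bonds along the chain from an amide-type nitrogen and a carbonyl carbon, gives a 2.0-fold lower number from compound 2 to compound 3 (0.30 log units; within the scatter) and hydrogen in place of (benzyloxycarbonyl)methyl at that same carbon gives a 1.4-fold lower number from compound 1 to compound 3 (0.14 log units; within the scatter), with both steps within the scatter. The earlier pair showed only that one chain end could be exchanged for another, whereas these two steps show that the whole chain can be replaced by hydrogen without a shift beyond the scatter, so neither the methylsulfanyl end nor the benzyloxycarbonyl end is required for a number in this range in this assay. Nothing at hand accounts for this tolerance at the position.

Still open, as far as these compounds go, is whether the tolerance extends to chains ending in an amine or a free carboxylic acid, or to a ring such as phenyl carried on a short chain at this carbon, any of which could move the number beyond the scatter. From the compounds shown here alone, all three compounds also share the benzyl ester, so the effect of a free carboxylic acid in its place remains unknown.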